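Swapping an amide for a sulfonamide on the ring nitrogen

A few compounds are considered here, and "the series" means these few. Any claim that something is new, unique, unknown or untested is made for them only; others in the source may bear on it.

Three compounds share one core and differ only in what sits on the amine nitrogen in the ring. Compound 1 `CN1CCc2nc(C#Cc3ccccc3)sc2C1` carries a methyl there; in an assay on HEK293 cells for negative allosteric modulation of metabotropic glutamate receptor 5 (Homo sapiens), read by FLIPR, with a stated time of 1 h (a higher number here means a weaker inhibitor, a lower number a stronger inhibitor), compound 1 reaches only the limit > 10000 nM. Compound 2 `CC(C)CN1CCc2nc(C#Cc3ccccc3)sc2C1` carries an isobutyl, and in this assay compound 2 gives 650 nM. Compound 3 `O=C(C1CCCO1)N1CCc2nc(C#Cc3ccccc3)sc2C1` carries an (oxolan-2-yl)carbonyl, and in this assay compound 3 also stops at the limit > 10000 nM. Thus compound 3 stands with compound 1 at the top edge of what the assay can read, which is where two of the three values sit (the limit of > 10000 nM in this assay, at which 2 of the 3 values shown sit). The step of an at least 15-fold higher number from compound 2 to compound 3 (1.18 log units; beyond the scatter) shows how far compound 3 trails compound 2, while a step that the two limits leave unreadable from compound 1 to compound 3 cannot be sized.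

Compound 4 `CC(C)S(=O)(=O)N1CCc2nc(C#Cc3ccccc3)sc2C1` makes one change: isopropylsulfonyl in place of (oxolan-2-yl)carbonyl on an amine nitrogen in a ring. For the measured compounds named here, no measured step tests this exact exchange. Both groups are non-basic and both leave the nitrogen bearing two acceptor oxygens, so compound 4 is expected to stay near the limit, a step that the limit leaves unreadable from compound 3 to compound 4. The value for compound 4 is therefore estimated at 15000 nM, within 3000 nM to 50000 nM.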

Compound 4, half-maximal inhibitory concentration: 11 nM
The estimate for compound 4 lay 1400-fold (3.13 log units) above the measured number; the measured number lies below the stated range.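

In this assay, for the compounds shown here, the amine nitrogen in a ring proves far more sensitive to the exact group than the earlier compounds showed: isopropylsulfonyl in place of (oxolan-2-yl)carbonyl gives an at least 900-fold lower number from compound 3 to compound 4 (2.95 log units; beyond the scatter), even though both groups count the same number of hydrogen-bond acceptors. Compound 4 also passes the best earlier compound, with a 59-fold lower number from compound 2 to compound 4 (1.77 log units; beyond the scatter), which makes compound 4 the strongest inhibitor of the four. Against the methyl group, the change gives an at least 900-fold lower number from compound 1 to compound 4 (2.95 log units; beyond the scatter); this step and the one from the (oxolan-2-yl)carbonyl compound give only a minimum size, as each starts from a limit: the limit of > 10000 nM in this assay, at which 2 of the 4 values shown sit.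

As far as these compounds go, whether the sulfonyl or its isopropyl matters more stays open. A methylsulfonyl or a phenylsulfonyl on this nitrogen, or an isobutyryl in place of the isopropylsulfonyl, would help to separate the two.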